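Phenoxy addition on the benzamide ring of compound 1

The compounds below may be only part of what the source reports. "The series", "measured", "known", "first", "only" and "open" are said of these compounds alone.

Measured so far:
Compound 1 `Cc1cccc(NC(=O)c2ccccc2)n1`: 35000 nM
Compound 2 `O=C(Nc1ccccn1)c1ccccc1`: 95400 nM

In an assay on membranes from brain for binding affinity to metabotropic glutamate receptor 5 (Rattus norvegicus) (on this read-out lower numbers stand for stronger inhibition and higher numbers for weaker inhibition), compound 1 gives 35000 nM, the lowest of the two numbers; compound 2 gives 95400 nM, the step being a 2.7-fold higher number from compound 1 to compound 2 (0.44 log units; beyond the scatter) for hydrogen in place of methyl on an aromatic carbon. Compound 3 `Cc1cccc(NC(=O)c2cccc(Oc3ccccc3)c2)n1` is not yet measured. It differs from compound 1 by phenoxy in place of hydrogen on an aromatic carbon, placed on an aromatic carbon of a six-membered aromatic ring of carbon only, meta to a large group. Within the data shown here, no measured step touches this ring; the only step known concerns the other ring and was modest. There is thus no direct ground for a large change in this assay either way, and a modest move within or just beyond the scatter is the expectation. Compound 3 is expected to give 15000 nM, ranging from 3000 nM to 70000 nM. That corresponds to an expected step of a 2.3-fold lower number from compound 1 to compound 3 (0.37 log units; beyond the scatter).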

Compound 3, half-maximal inhibitory concentration: 57000 nM
Compound 3: the middle estimate sits 3.8-fold (0.58 log units) below what was measured, within the range that was stated.
By their numbers in this assay, from the lowest: compounds 1, 3 and 2 (each within the scatter of the next, the first and the last beyond it).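

In this assay the step from hydrogen to phenoxy gives a 1.6-fold higher number from compound 1 to compound 3 (0.21 log units; within the scatter) and so stays within the scatter, which shows that a group of 7 heavy atoms, including a six-membered aromatic ring of carbon only, is accepted at this place, meta to a large group, without a readable gain or loss. Among these compounds, the earlier step, a 2.7-fold higher number from compound 1 to compound 2 (0.44 log units; beyond the scatter), concerned only the other ring, so this is the first reading on the ring of carbon only, and it gives no sign that this position offers a route to much lower numbers. No supporting data bear on this result.

As far as these compounds go, whether a smaller group here, such as methoxy, chlorine or an amine, would move the number beyond the scatter stays open. Also open, from the compounds shown here alone, is whether phenoxy would behave alike on the core of compound 2, which lacks the methyl.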